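Propyl to Isopropyl Ester Change on Two Cores

This account rests on a few compounds, and the source may have more. Where it says the series, first, only, none or still open, it means among the compounds named here.

Compound 1, `CCCOC(=O)C(Cn1ccnc1)NC(=O)c1ccc(-c2ccccc2)cc1`: 790 nM in an assay on HL-60 cells for inhibition of cytochrome P450 26A1 (Homo sapiens), read by HPLC, using microsomes and NADPH, with a stated time of 30 min; on this read-out lower numbers stand for stronger inhibition and higher numbers for weaker inhibition
Compound 2, `CC(C)OC(=O)C(Cn1ccnc1)NC(=O)c1ccc(-c2ccccc2)cc1`: 540 nM in this assay
Compound 3, `CCCOC(=O)C(Cn1ccnc1)NC(=O)c1c(C)nn(-c2ccccc2)c1Cl`: 620 nM in this assay

Compound 1 and compound 2 share one core and differ only in the ester: isopropyl in place of propyl on an oxygen next to a carbonyl group. This change gave a 1.5-fold lower number from compound 1 to compound 2 (0.17 log units; within the scatter), so the two esters read as equivalent within the scatter. Compound 3 carries a different core; the difference between the two cores is not broken down here, and the values of compound 3 and compound 2 lie within the scatter of each other.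

Compound 4, `Cc1nn(-c2ccccc2)c(Cl)c1C(=O)NC(Cn1ccnc1)C(=O)OC(C)C`, has not yet been measured in this assay. It repeats the same change on the core of compound 3: isopropyl in place of propyl on an oxygen next to a carbonyl group. Among the compounds shown this change occurs twice. Because the earlier instance gave a 1.5-fold lower number from compound 1 to compound 2 (0.17 log units; within the scatter), a step of about the same small size is expected here, a 1.5-fold lower number from compound 3 to compound 4 (0.17 log units; within the scatter), resting on that one precedent alone. Compound 4 is therefore estimated at 420 nM, with a range from 200 nM to 900 nM.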

Compound 4, half-maximal inhibitory concentration: 460 nM
Estimate against measurement, compound 4: 1.1-fold (0.04 log units) below; the range from low to high includes it.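

On the second core, isopropyl in place of propyl gave a 1.3-fold lower number from compound 3 to compound 4 (0.13 log units; within the scatter) in this assay, so here too the two esters read as equivalent. Set beside the first core, the change carried over with no difference that can be told apart from the scatter: the same change on two cores in this assay, a 1.5-fold lower number (0.17 log units; within the scatter) from compound 1 to compound 2 and a 1.3-fold lower number (0.13 log units; within the scatter) from compound 3 to compound 4, 1.1-fold (0.04 log units) apart, within the scatter of two such steps. Each step lies within the scatter, so the pair shows that this swap stayed small on both cores, but it shows no real preference for isopropyl over propyl, and two cores say nothing about how the change would behave on a further core.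

The compounds shown leave open whether a longer chain such as butyl, a smaller ester such as methyl, or a free carboxylic acid on that carbonyl group would read differently from the propyl and isopropyl esters. They also leave open what the two cores themselves contribute, as the difference between them is not broken down here.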